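The source may hold more compounds than are shown below. What is called first, only, known or untested is meant among the compounds shown, and "the series" means these compounds.

In an ADME assay on LLC-PK1 cells (Sus scrofa) for permeability (a lower number here means that the compound crosses the layer more slowly, a higher number that the compound crosses the layer faster), compound 1 (`C[C@H](NC(=O)CCN1CCC(c2nc(-c3ccccn3)no2)CC1)c1ccc(Cl)cc1`) gives 31 10^-6 cm/s and compound 2 (`O=C(CCN1CCC(c2nc(-c3ccccn3)no2)CC1)NC(c1ccccc1)c1ccc(Cl)cc1`) gives 24 10^-6 cm/s as its value, so these two numbers lie within the scatter of each other. Compound 3 (`O=C(CCN1CCC(c2nc(-c3ccccn3)no2)CC1)NC(c1ccncc1)c1ccc(Cl)cc1`) carries pyridin-4-yl in place of phenyl on a saturated chain carbon bound to an amide-type nitrogen and an aromatic carbon. Among the compounds with values here, no measured step covers this change. In this assay a moderate fall is expected, with a 1.5-fold lower number from compound 2 to compound 3 (0.18 log units; within the scatter) as the estimated step. For compound 3 the estimate is 16 10^-6 cm/s as the middle, with a range of 8 10^-6 cm/s to 28 10^-6 cm/s expected.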

Compound 3, apparent permeability: 30 10^-6 cm/s
Compound 3: middle estimate off by 1.9-fold (0.27 log units), on the low side; measured number outside the range, above it.
By their numbers in this assay, from the lowest: compounds 2, 3 and 1 (each within the scatter of the next).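

In this assay, pyridin-4-yl in place of phenyl on a saturated chain carbon bound to an amide-type nitrogen and an aromatic carbon gives a 1.3-fold higher number from compound 2 to compound 3 (0.10 log units; within the scatter). This position therefore accepts one ring nitrogen, with its added hydrogen-bond acceptor, without a step beyond the scatter, which compounds 1 and 2 alone could not show. Nothing measured on these compounds accounts for this result.

Still open, from the compounds shown here alone, is whether pyridin-2-yl or pyridin-3-yl on the same carbon would also stay within the scatter of compound 2. A phenyl ring carrying a carboxylic acid or an amine there is equally untested by the compounds shown.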